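The source may hold more compounds than are shown below. What is called first, only, known or untested is meant among the compounds shown, and "the series" means these compounds.

Compound 1 `CC(C)(C)c1ccc(CNC(=S)NC2(c3ccc(NS(C)(=O)=O)cc3)CC2)cc1`: 171 nM
Compound 2 `CC(C)(C)c1ccc(CNC(=S)NC(C)(C)c2ccc(NS(C)(=O)=O)c(F)c2)cc1`: 7700 nM

Going by the values given here, in an assay on CHO cells for displacement of a labelled ligand from transient receptor potential cation channel subfamily V member 1 (Rattus norvegicus) (a lower number here means a stronger inhibitor, a higher number a weaker inhibitor), compound 1 gives 171 nM, the lower of the two numbers measured so far. Compound 2, which differs from it at several places, gives 7700 nM, a much higher number that lies well beyond the usual scatter, so compound 1 is the stronger binder of the pair.

Compound 3 `COc1cc(C2(NC(=S)NCc3ccc(C(C)(C)C)cc3)CC2)ccc1NS(C)(=O)=O` has not yet been measured. It keeps the whole of compound 1 and changes only one spot: methoxy in place of hydrogen on an aromatic carbon, the new group sitting ortho to a methanesulfonamido group. Among the compounds with values here, no pair of measured compounds isolates this single change, so there is no direct precedent to lean on, only the observation that a substituent on that same ring, combined with other changes, came with a weaker result for compound 2 at 7700 nM.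

On that basis compound 3 is expected to bind somewhat more weakly than compound 1, by a step of a 2.3-fold higher number from compound 1 to compound 3 (0.37 log units; beyond the scatter) in this assay. The estimate for compound 3 is 400 nM, within a range of 100 nM to 1600 nM.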

Compound 3, inhibition constant: 370 nM
The estimate for compound 3 lay 1.1-fold (0.03 log units) above the measured number; the measured number falls inside the stated range.
By their numbers in this assay, from the lowest: compound 1; then compound 3; then compound 2.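

In this assay, methoxy in place of hydrogen on an aromatic carbon, ortho to a methanesulfonamido group, comes with a modest but real change: a 2.2-fold higher number from compound 1 to compound 3 (0.34 log units; beyond the scatter). Going by these compounds alone, this is the first view of a single change on that ring, since compound 2 also carries a substituent there but differs from compound 1 in several places, so its number cannot be assigned to any one of them. The position accepts methoxy at a limited cost, with compound 3 still giving 370 nM, although no accompanying measurement on these compounds gives a reason for the rise.

From the compounds shown here alone, one group at one place says little about the position as a whole, so it remains open whether a hydroxyl group, a chlorine atom, an amine or a longer chain such as ethoxy at the same carbon would give a number close to that of compound 1 or move further from it. Going by these compounds, it also remains open whether methoxy would give a step of similar size on another carbon of the same ring, or on a compound with a different core.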